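The source may report more compounds than this note shows. Statements on the series, on what has been measured and on what is new or still open speak of the compounds shown alone.

In a functional assay on HCT-8 cells (Homo sapiens) for antiproliferative activity, read by MTT assay, with a stated time of 48 h (a higher number here means a weaker inhibitor, a lower number a stronger inhibitor), compound 2 `COc1ccc(C(=O)c2ccc3c(c2)C=CC(C)(C)O3)c(NC(=O)CBr)c1` gives 3260 nM and compound 1 `COc1ccc(C(=O)c2ccc(OC)c3c2OC(C)(C)C=C3)c(NC(=O)CBr)c1` gives 3250 nM, two values that lie within the usual scatter of each other. Compound 3 `COc1ccc(C(=O)c2ccc(OC)c3c2C=CC(C)(C)O3)c(NC(=O)CO)c1` gives 630 nM and so stands lower than compound 2, beyond the scatter, which makes it the stronger inhibitor of that pair.

Compound 4 `COc1ccc(C(=O)c2ccc3c(c2)C=CC(C)(C)O3)c(NC(=O)CO)c1` has not yet been measured. It departs from compound 2 by a single swap (hydroxy in place of bromo on a saturated chain carbon bound to a carbonyl carbon): hydroxy in place of bromo on a saturated chain carbon bound to a carbonyl carbon.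

Among the measured compounds shown here, no measured pair shows this swap alone, since compound 3 carries the hydroxy group but its core also differs from that of compound 2. For the measured compounds named here, compound 3 at 630 nM is still the only guide, so a move to a lower number, meaning a stronger inhibitor, is expected, probably just beyond the scatter. The expected move (a 3.3-fold lower number from compound 2 to compound 4 (0.51 log units; beyond the scatter)) is only an estimate. Compound 4 is expected to give 1000 nM within an estimated range from 350 nM to 3000 nM once tested.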

Compound 4, half-maximal inhibitory concentration: 250 nM
Compound 4: middle estimate off by 4.0-fold (0.60 log units), on the high side; measured number outside the range, below it.
By their numbers in this assay, from the lowest: compound 4; then compound 3; then compounds 1 and 2 (each within the scatter of the next).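

Among the compounds shown here, the swap of bromo for hydroxy on a saturated chain carbon bound to a carbonyl carbon can now be read on its own for the first time: in this assay it gives a 13-fold lower number from compound 2 to compound 4 (1.12 log units; beyond the scatter), a large change from one atom. So this chain position matters for the antiproliferative effect, and on this core the bromo group is not required, since the hydroxy compound is the stronger inhibitor of the pair. Nothing measured here explains why this swap has such an effect.

From the compounds shown here alone, it remains open whether an amine, a fluoro group or a longer chain ending in hydroxy would do as well as hydroxy at this place. Going by these compounds, it is also open whether the same swap would give a step of similar size on the core of compound 1.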